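Swapping the aryl group on an amine nitrogen

This account rests on a few compounds, and the source may have more. Where it says the series, first, only, none or still open, it means among the compounds named here.

Measured in a functional assay on ECa-109 cells for inhibition, with ECa-109 cell line (Homo sapiens) as the target, read by sulforhodamine B assay; a higher number here means a weaker inhibitor, a lower number a stronger inhibitor:
compound 1 `O=C1C(Nc2ccccc2F)=CC(=O)c2c1nc1n2[C@H]2OC[C@@H](O)[C@H]2OC1` (2660 nM)
compound 2 `Cc1ccc(NC2=CC(=O)c3c(nc4n3[C@H]3OC[C@@H](O)[C@H]3OC4)C2=O)cc1C` (4090 nM)
compound 3 `O=C1C(Nc2ccc(C(F)(F)F)cc2)=CC(=O)c2c1nc1n2[C@H]2OC[C@@H](O)[C@H]2OC1` (2250 nM)

Compound 3 stands within the scatter of the other two, with a 1.2-fold lower number from compound 1 to compound 3 (0.07 log units; within the scatter) and a 1.8-fold lower number from compound 2 to compound 3 (0.26 log units; within the scatter). Compound 4 `COc1cccc(NC2=CC(=O)c3c(nc4n3[C@H]3OC[C@@H](O)[C@H]3OC4)C2=O)c1` carries 3-methoxyphenyl in place of 4-(trifluoromethyl)phenyl on an amine nitrogen. The measured swaps at that nitrogen bear on this change, and a 1.5-fold higher number from compound 1 to compound 2 (0.19 log units; within the scatter) also stays within the scatter. Within the data shown here, no measured compound carries 3-methoxyphenyl, so the expectation rests on these steps alone. No step beyond the scatter is expected in this assay, in either direction. The estimated change is a 1.3-fold higher number from compound 3 to compound 4 (0.11 log units; within the scatter). For compound 4 the expected value is 2900 nM, with an estimated range from 1500 nM to 5500 nM.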

Compound 4, half-maximal inhibitory concentration: 3340 nM
Beside the measured number, compound 4's estimate is 1.2-fold (0.06 log units) below it; the measured number falls inside the stated range.
By their numbers in this assay, from the lowest: compounds 3, 1, 4 and 2 (each within the scatter of the next).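

With 3-methoxyphenyl on the amine nitrogen in this assay the shift is small in every comparison, with a 1.5-fold higher number from compound 3 to compound 4 (0.17 log units; within the scatter) and a 1.2-fold lower number from compound 2 to compound 4 (0.09 log units; within the scatter) and a 1.3-fold higher number from compound 1 to compound 4 (0.10 log units; within the scatter) all within the scatter. The only one of the four aryl groups to bring an oxygen and a hydrogen-bond acceptor to this position therefore stays level with the others, and all four compounds lie within the scatter of one another. No evidence is available to explain this.

As far as these compounds go, whether a carboxylic acid on the aryl ring, or a straight alkyl chain in its place, would also leave the number within the scatter remains open.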